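Swapping the nitrile of compound 1 for a thioamide

A few compounds are considered here, and "the series" means these few. Any claim that something is new, unique, unknown or untested is made for them only; others in the source may bear on it.

Measured compounds:
compound 1 `N#Cc1cn([C@H]2C[C@H](O)[C@@H](CO)O2)c2ncnc(N)c12` with 80000 nM
compound 2 `N#Cc1cn(C2OC(CO)CC2O)c2ncnc(N)c12` with 100 nM
compound 3 `N#Cc1cn([C@@H]2O[C@H](CO)[C@@H](O)[C@@H]2N)c2ncnc(N)c12` with 100000 nM

In a functional assay on L1210 cells (Mus musculus) for inhibition (a lower number here means a stronger inhibitor, a higher number a weaker inhibitor), compound 1 stands second highest of the three numbers. Its nearest neighbour is compound 3, and the step of a 1.3-fold higher number from compound 1 to compound 3 (0.10 log units; within the scatter) sits within the scatter; compound 2 lies far lower, beyond the scatter.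

Compound 4 `NC(=S)c1cn([C@H]2C[C@H](O)[C@@H](CO)O2)c2ncnc(N)c12` has not been measured. It differs from compound 1 in one place: a group of 3 heavy atoms (1 carbon, 1 nitrogen, 1 sulfur; no ring) in place of a group of 2 heavy atoms (1 carbon, 1 nitrogen; no ring), on an aromatic carbon. For the measured compounds named here, no measured step touches the nitrile, so nothing among the three compounds shows how this exchange moves the number. Going by the values given here, the only measured step, a 1.3-fold higher number from compound 1 to compound 3 (0.10 log units; within the scatter), concerns a different position and gives no guidance here. The expectation is therefore a number close to compound 1, with wide uncertainty, so that the step of a 1.6-fold lower number from compound 1 to compound 4 (0.20 log units; within the scatter) is estimated to stay inside the scatter. For compound 4 the estimate is 50000 nM, expected between 10000 nM and 200000 nM.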

Compound 4, half-maximal inhibitory concentration: 3900 nM
Compound 4: the middle estimate sits 13-fold (1.11 log units) above what was measured; the measured number lies below the stated range.
By their numbers in this assay, from the lowest: compound 2; then compound 4; then compounds 1 and 3 (each within the scatter of the next).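

In this assay the aromatic carbon bearing the nitrile proves sensitive to change: a thioamide there gives a 21-fold lower number from compound 1 to compound 4 (1.31 log units; beyond the scatter) for a stronger inhibitor on the same core. The exchange adds a sulfur atom and a hydrogen-bond donor, but these counts alone do not show which feature matters. Nothing available explains the size of this step. As far as these compounds go, it remains open whether a carboxamide, with oxygen in place of sulfur, or a carboxylic acid on this carbon would act similarly. From the compounds shown here alone, whether the thioamide would have the same effect on the core of compound 3 is also open.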